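Swapping the ring on the sulfonyl arm of compound 2

The compounds below may be only part of what the source reports. "The series", "measured", "known", "first", "only" and "open" are said of these compounds alone.

Measured compounds:
compound 1 `O=S(=O)(CC1=NCCO1)C1C(c2ccc(Cl)cc2)=NN(c2ccccc2)C1c1ccc(Cl)cc1` — in a functional assay, tested at 75 ug/mL (on this read-out higher numbers stand for a stronger effect at the one concentration tested and lower numbers for a weaker effect), compound 1 is reported as "not active" (no number reported)
compound 2 `O=S(=O)(CC1=NCCO1)c1c(-c2ccccc2)nn(-c2ccccc2)c1-c1ccccc1` — in this assay compound 2 gives 57.3%
compound 3 `Cc1ccc(C2CNN=C2S(=O)(=O)CC2=NCCS2)cc1` — in this assay compound 3 gives 42.2%

Among the two numbers available, compound 2 stands highest; compound 3 is the nearest, and its value lies beyond the usual scatter below that of compound 2. Compound 1 carries no number at all, only the statement that it was not active.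

The unmeasured compound 4 `O=S(=O)(CC1=NCCS1)c1c(-c2ccccc2)nn(-c2ccccc2)c1-c1ccccc1` is built from compound 2 by a single exchange on a saturated chain carbon bound to a sulfonyl sulfur: a group of 5 heavy atoms (3 carbon, 1 nitrogen, 1 sulfur; one five-membered non-aromatic ring with 2 hetero atoms) in place of a group of 5 heavy atoms (3 carbon, 1 nitrogen, 1 oxygen; one five-membered non-aromatic ring with 2 hetero atoms), on a saturated chain carbon bound to a sulfonyl sulfur. Going by the values given here, no pair of measured compounds differs in just this one place, so the step cannot be read from the data; compound 3 does carry a ring with a sulfur, but its core differs from that of compound 2 as well, so its lower value says nothing direct about this exchange.

The change is expected to be small, within the scatter, and the expected step from compound 2 to compound 4 is a number 5.3 percentage points lower from compound 2 to compound 4 (within the scatter). Compound 4 is therefore estimated at 52%, with a range from 35% to 70%.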

Compound 4, a percentage reported as activity, at one concentration (the size of the read-out at that concentration, not a potency): "not active" (no number reported)
No number was reported for compound 4; the estimate stays without a comparison.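

Going by these compounds alone, compound 4 carries no number in this assay, only the statement "not active" (no number reported), so no step from compound 2 to compound 4 can be read. Nothing shown offers an explanation for this result. Left open is what the single exchange of the oxygen-bearing ring for the sulfur-bearing ring does on its own.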